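This account rests on a few compounds, and the source may have more. Where it says the series, first, only, none or still open, it means among the compounds named here.

Series notes, amide substituent on the shared core.

Among the measured compounds shown here, compound 1 `CCn1c(C(=O)NCCN)ccc1C(CC)(CC)c1ccc(OCCC(O)(CC)CC)c(C)c1` gives 1740 nM in a functional assay on Caco-2 cells (Homo sapiens) for antiproliferative activity, read by MTT assay, with a stated time of 48 h (a higher number here means a weaker inhibitor, a lower number a stronger inhibitor), the lowest of the three numbers measured so far. Compound 3 `CCn1c(C(=O)N(C)CC(=O)O)ccc1C(CC)(CC)c1ccc(OCCC(O)(CC)CC)c(C)c1` gives 2740 nM, and the change a 1.6-fold higher number from compound 1 to compound 3 (0.20 log units; within the scatter) stays within the scatter. Compound 2 `CCC(C)C(NC(=O)c1ccc(C(CC)(CC)c2ccc(OCCC(O)(CC)CC)c(C)c2)n1CC)C(=O)O` gives 20000 nM; here an 11-fold higher number from compound 1 to compound 2 (1.06 log units; beyond the scatter) is a large loss, and a 7.3-fold lower number from compound 2 to compound 3 (0.86 log units; beyond the scatter) recovers most of it.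

Compound 4 `CCn1c(C(=O)NC(CO)CCO)ccc1C(CC)(CC)c1ccc(OCCC(O)(CC)CC)c(C)c1` has not been measured. It differs from compound 1 in one place: 3-hydroxy-1-(hydroxymethyl)propyl in place of 2-aminoethyl on an amide-type nitrogen

For the measured compounds named here, two measured steps bear on this. The step to compound 3 shows that removing the amine of the 2-aminoethyl group costs little, while the step to compound 2 shows that a larger carboxy-bearing group in the same place costs much. Compound 4 carries a larger group without a carboxylic acid, so an intermediate outcome is expected, a weakening that is modest rather than large. Compound 4 is therefore estimated at 4000 nM, with a range of 1500 nM to 12000 nM, which means an expected step of a 2.3-fold higher number from compound 1 to compound 4 (0.36 log units; beyond the scatter).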

Compound 4, half-maximal inhibitory concentration: 40200 nM
Estimate against measurement, compound 4: 10-fold (1.00 log units) below; the whole stated range lies below it.
By their numbers in this assay, from the lowest: compounds 1 and 3 (each within the scatter of the next); then compounds 2 and 4 (each within the scatter of the next).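

At the amide-type nitrogen, 3-hydroxy-1-(hydroxymethyl)propyl gives a 23-fold higher number from compound 1 to compound 4 (1.36 log units; beyond the scatter) in this assay, so a large loss on this nitrogen does not require a carboxylic acid in the substituent. The same group gives a 15-fold higher number from compound 3 to compound 4 (1.17 log units; beyond the scatter) on the carbonyl carbon, which shows that this position does not accept every substituent even though compound 1 and compound 3 lie within the scatter of each other. With a 2.0-fold higher number from compound 2 to compound 4 (0.30 log units; within the scatter) the uncharged diol and the 1-carboxy-2-methylbutyl group cannot be separated here, so the carboxylic acid of compound 2 is not needed to reach this level.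

Open, as far as these compounds go, is whether an unbranched 2-hydroxyethyl group or a longer aminoalkyl chain on this nitrogen would hold the number of compound 1. No measured evidence is at hand on what lies behind these losses.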